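This account rests on a few compounds, and the source may have more. Where it says the series, first, only, none or still open, it means among the compounds named here.

Compound 1 `CCC(CC)(c1ccc(OS(=O)(=O)c2ccc(C)cc2)c(C)c1)c1ccc(OCC(=O)C(C)(C)C)c(OCC(=O)C(C)(C)C)c1`: 35%
Compound 2 `CCC(CC)(c1ccc(OCCCO)c(C)c1)c1ccc(OCC(O)C(C)(C)C)c(OCC(O)C(C)(C)C)c1`: 76%

Of the compounds shown here, two have been measured in an assay on cells for binding affinity to vitamin D3 receptor (Homo sapiens), read by fluorescence, tested at 1 uM; a higher number here means more inhibition at the concentration tested (going by the name of the read-out), a lower number less inhibition. Compound 1 gives 35%, while compound 2 gives 76%, the higher of the two numbers and separated from compound 1 by a gap beyond the usual scatter. Within the data shown here, no single-change step between these two compounds is recorded, so only what their two values show can be said of them.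

Compound 3 `CCC(CC)(c1ccc(OCCCCCCO)c(C)c1)c1ccc(OCC(O)C(C)(C)C)c(OCC(O)C(C)(C)C)c1` has not been measured. It differs from compound 2 by 3-hydroxypropyl in place of hydroxy on a saturated chain carbon, three bonds along the chain from an oxygen on an aromatic ring. Nothing in the measured pair speaks directly to a change of this kind, so the expectation rests on the value of compound 2 alone. The step of a number 8 percentage points lower from compound 2 to compound 3 (within the scatter) is expected to be small, most likely a slight fall that stays within or only just beyond the scatter. Compound 3 is therefore estimated at 68%, with a range from 45% to 85%.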

Compound 3, a percentage reported as inhibition, at one concentration (the size of the read-out at that concentration, not a potency): 52%
For compound 3 the middle estimate is 16 percentage points above the measured one, and the stated range covers the measured number.
By their numbers in this assay, from the lowest: compound 1; then compound 3; then compound 2.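

Among these compounds, with compound 3, a single change at this position can be read for the first time: in this assay, 3-hydroxypropyl in place of hydroxy on a saturated chain carbon, three bonds along the chain from an oxygen on an aromatic ring, gives a number 24 percentage points lower from compound 2 to compound 3 (beyond the scatter) and leaves the rest of the structure untouched. The position is therefore not indifferent to this extension, even though the 6-hydroxyhexyl chain of compound 3 still ends in a hydroxy group, as the 3-hydroxypropyl chain of compound 2 does. Nothing available explains the fall.

The compounds shown leave open whether the number falls gradually or abruptly through the 4-hydroxybutyl and 5-hydroxypentyl chains. They also leave open how a carboxylic acid or an amine would fare in place of the terminal hydroxy.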